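A few compounds are considered here, and "the series" means these few. Any claim that something is new, unique, unknown or untested is made for them only; others in the source may bear on it.

In a physicochemical assay for acid dissociation, compound 1 `C#CC(C)OC[n+]1ccn(C)c1/C=N/O` gives 7.96, compound 2 `C#CC(CC)OC[n+]1ccn(C)c1/C=N/O` gives 7.99 and compound 3 `C#CCC(C)OC[n+]1ccn(C)c1/C=N/O` gives 8.03. Compound 3 therefore stands level with the other two, within the scatter. Compound 4 `C#CCC(OC[n+]1ccn(C)c1/C=N/O)c1ccccc1` is still unmeasured. The change is phenyl in place of methyl on a saturated chain carbon bound to an oxygen on a saturated carbon and a saturated chain carbon.

Among the measured compounds shown here, three measured steps bear on this change: a number 0.03 log units higher from compound 1 to compound 2 (within the scatter), a number 0.07 log units higher from compound 1 to compound 3 (within the scatter) and a number 0.04 log units higher from compound 2 to compound 3 (within the scatter). All three are small and lie within the scatter. For the measured compounds named here, none of them brings in a ring, so the series holds no direct precedent for phenyl, and the expectation is an extrapolation. These steps give no direction, and no step beyond the scatter is expected in this assay. The expected step is a number 0.03 log units lower from compound 3 to compound 4 (within the scatter). The estimate for compound 4 is 8, with an expected range of 7.75 to 8.25.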

Compound 4, acid dissociation constant: 7.99
The estimate for compound 4 lay 0.01 log units above the measured number; low and high end bracket the measured number.
By their numbers in this assay, from the lowest: compounds 1, 2, 4 and 3 (each within the scatter of the next).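

In this assay, among the compounds shown here, phenyl in place of methyl on a saturated chain carbon bound to an oxygen on a saturated carbon and a saturated chain carbon gives a number 0.04 log units lower from compound 3 to compound 4 (within the scatter) and is the first step to bring in a ring. The earlier steps shown here exchanged only open-chain groups, whereas this one shows that a six-membered aromatic ring of carbon only also leaves the reading within the scatter at this position. No measurement at hand offers a reason for this result.

As far as these compounds go, whether an amine or a carboxylic acid on this same saturated chain carbon would also stay within the scatter remains open. From the compounds shown here alone, it is equally open whether a phenyl carrying a nitrile would match the plain phenyl of compound 4.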